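Amide Variation on a Coumarin-Type Nitric Oxide Donor Series

This account rests on a few compounds, and the source may have more. Where it says the series, first, only, none or still open, it means among the compounds named here.

Measured compounds:
compound 1 `COc1cc2cc(C(=O)NCCCc3ccccc3)c(=O)oc2cc1OCCCOc1no[n+]([O-])c1S(=O)(=O)c1ccccc1` — 870 nM
compound 2 `COc1cc2cc(C(=O)NCCCc3ccc(F)cc3)c(=O)oc2cc1OCCCOc1no[n+]([O-])c1S(=O)(=O)c1ccccc1` — 600 nM

In a functional assay on MCF7 cells (Homo sapiens) for inhibition, read by MTT assay, with a stated time of 48 h (a higher number here means a weaker inhibitor, a lower number a stronger inhibitor), compound 2 gives the lowest of the two numbers shown, and its only neighbour, compound 1, sits within the scatter of it, so the two cannot be ordered. For the measured compounds named here, the one measured step, a 1.5-fold lower number from compound 1 to compound 2 (0.16 log units; within the scatter), is small. Compound 3 `COc1ccc(NC(=O)c2cc3cc(OC)c(OCCCOc4no[n+]([O-])c4S(=O)(=O)c4ccccc4)cc3oc2=O)cc1` differs from compound 2 by 4-methoxyphenyl in place of 3-(4-fluorophenyl)propyl on an amide-type nitrogen. Going by the values given here, no measured step touches the amide substituent itself, so nothing here speaks for a shift in either direction; the step is expected to be a 1.3-fold higher number from compound 2 to compound 3 (0.12 log units; within the scatter). Compound 3 is therefore estimated at 800 nM, with a range of 250 nM to 2500 nM.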

Compound 3, half-maximal inhibitory concentration: 410 nM
The estimate for compound 3 lay 2.0-fold (0.29 log units) above the measured number; the range from low to high includes it.
By their numbers in this assay, from the lowest: compounds 3, 2 and 1 (each within the scatter of the next, the first and the last beyond it).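

In this assay, for the compounds shown here, the amide substituent gives the first step that clears the scatter: 4-methoxyphenyl in place of 3-phenylpropyl gives a 2.1-fold lower number from compound 1 to compound 3 (0.33 log units; beyond the scatter), a modest step. Against the fluorinated chain, the same group gives a 1.5-fold lower number from compound 2 to compound 3 (0.17 log units; within the scatter), so those two compounds cannot be ordered. No available evidence bears on this result. The compounds shown leave open how a longer chain on the amide nitrogen would read here. They also leave open the effect of an amine or a carboxylic acid in place of the methoxy group.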